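Swapping the aryl group on a sulfonamide nitrogen

The source may hold more compounds than are shown below. What is called first, only, known or untested is meant among the compounds shown, and "the series" means these compounds.

Compound 1, `COc1ccc(S(=O)(=O)Nc2cc(Cl)cc(Cl)c2)cc1N1CCNCC1`: 0.631 nM
Compound 2, `COc1ccc(Cl)cc1NS(=O)(=O)c1ccc(OC)c(N2CCNCC2)c1`: 1.26 nM

Both values come from an assay on isolated protein for binding affinity to 5-hydroxytryptamine receptor 6 (Homo sapiens); on this read-out higher numbers stand for weaker inhibition and lower numbers for stronger inhibition. Going by the values given here, compound 2 stands highest of the two numbers, yet its only neighbour, compound 1, is separated from it by a step that lies within the scatter: a 2.0-fold higher number from compound 1 to compound 2 (0.30 log units; within the scatter). Compound 3, `COc1ccc(S(=O)(=O)Nc2ccc(C)cc2Br)cc1N1CCNCC1`, has not been measured. It differs from compound 2 in one place: 2-bromo-4-methylphenyl in place of 5-chloro-2-methoxyphenyl on a sulfonamide nitrogen. Among the compounds with values here, the only measured step that bears on this change is the one from compound 1 to compound 2, which also exchanged the aryl group on the sulfonamide nitrogen and produced only a shift within the scatter. On that basis no change beyond the scatter is expected for compound 3 in this assay, a 1.2-fold higher number from compound 2 to compound 3 (0.08 log units; within the scatter). Compound 3 is therefore estimated to give about 1.5 nM in this assay, with a likely range from 0.4 nM to 6 nM.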

Compound 3, inhibition constant: 7.94 nM
The estimate for compound 3 lay 5.3-fold (0.72 log units) below the measured number; the measured number lies above the stated range.
By their numbers in this assay, from the lowest: compounds 1 and 2 (each within the scatter of the next); then compound 3.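

In this assay the aryl group on the sulfonamide nitrogen turns out to matter: 2-bromo-4-methylphenyl gives a 6.3-fold higher number from compound 2 to compound 3 (0.80 log units; beyond the scatter) and also a 13-fold higher number from compound 1 to compound 3 (1.10 log units; beyond the scatter) at this same position. So the close values of compound 1 and compound 2 do not mean that any aryl group is tolerated here, since a change at this position can move the number well beyond the scatter. No measurement on hand explains this rise.

Bromine and methyl enter together in compound 3, and the compounds shown do not separate their contributions. Also open, from the compounds shown here alone, is how this nitrogen would fare with an unsubstituted phenyl, or with an aryl group carrying an amine or a carboxylic acid.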